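Oxygen-to-sulfur linker change on the diamine series

A few compounds are considered here, and "the series" means these few. Any claim that something is new, unique, unknown or untested is made for them only; others in the source may bear on it.

Measured compounds:
compound 1 `Nc1cc(N)c2nc(-c3ccccc3)c(Oc3ccc(Cl)c(Cl)c3)nc2c1`, 47900 nM
compound 2 `COc1ccc(Sc2nc3cc(N)cc(N)c3nc2-c2ccccc2)cc1`, a limit of the assay, < 100000 nM
compound 3 `Nc1cc(N)c2nc(-c3ccccc3)c(Oc3ccc(F)cc3)nc2c1`, 81300 nM

In a functional assay on HCT-116 cells (Homo sapiens) for inhibition, read by sulforhodamine B assay, with a stated time of 48 h (on this read-out higher numbers stand for weaker inhibition of growth and lower numbers for stronger inhibition of growth), compound 3 gives 81300 nM, the higher of the two readable numbers; the step of a 1.7-fold higher number from compound 1 to compound 3 (0.23 log units; within the scatter) is within the scatter. For compound 2 only a limit is known, (the limit of < 100000 nM in this assay, at which 1 of the 3 values shown sits). Compound 4 `Nc1cc(N)c2nc(-c3ccccc3)c(Sc3ccc(F)cc3)nc2c1` differs from compound 3 by (4-fluorophenyl)sulfanyl in place of 4-fluorophenoxy on an aromatic carbon. Among the compounds with values here, the steps that touch a sulfur linker, a step that the limit leaves unreadable from compound 1 to compound 2 and a step that the limit leaves unreadable from compound 2 to compound 3, are both unreadable, so no measured step gives the size of an oxygen-to-sulfur change here. The expectation for compound 4 is therefore no step beyond the scatter, a 1.0-fold lower number from compound 3 to compound 4 (0.01 log units; within the scatter). Compound 4 is estimated at 80000 nM, within 30000 nM to 200000 nM.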

Compound 4, concentration for total growth inhibition: 28200 nM
For compound 4 the middle estimate is 2.8-fold (0.45 log units) above the measured one, outside the stated range (below it).
By their numbers in this assay, from the lowest: compounds 4, 1 and 3 (each within the scatter of the next, the first and the last beyond it).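

In this assay, the oxygen-to-sulfur change at this aromatic carbon can now be sized with the 4-fluorophenyl kept: a 2.9-fold lower number from compound 3 to compound 4 (0.46 log units; beyond the scatter). The (4-fluorophenyl)sulfanyl and 3,4-dichlorophenoxy groups are not told apart here, with a 1.7-fold lower number from compound 1 to compound 4 (0.23 log units; within the scatter). Compound 2 has only a limit, so the steps to it cannot be read: the limit of < 100000 nM in this assay, at which 1 of the 4 values shown sits.

From the compounds shown here alone, the size of the linker change therefore rests on a single matched pair, and whether it holds with other aryl groups stays open. Also open, going by these compounds, is how an amine or a longer alkyl chain on the sulfur, in place of the 4-fluorophenyl, would read.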